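Adding a methoxy group to compound 2

A few compounds are considered here, and "the series" means these few. Any claim that something is new, unique, unknown or untested is made for them only; others in the source may bear on it.

Compound 1 `Cn1cc(-c2ccccc2Oc2ccccc2)c2cc(C(=O)NCCCCCC(=O)NO)[nH]c2c1=O` gives 610 nM
Compound 2 `Cn1cc(-c2cccc(C(C)(C)O)c2)c2cc(C(=O)NCc3ccc(C(=O)Nc4ccccc4N)cc3)[nH]c2c1=O` gives 2200 nM
Compound 3 `Cc1cc(F)cc(C)c1Oc1ccc(C(C)(C)O)cc1-c1cn(C)c(=O)c2[nH]c(C(=O)NCCCCCCC(=O)NO)cc12` gives 300 nM

In a functional assay on MV4-11 cells (Homo sapiens) for antiproliferative activity, read by CCK-8 assay, with a stated time of 72 h (on this read-out lower numbers stand for stronger inhibition and higher numbers for weaker inhibition), compound 2 stands at 2200 nM as the highest of the three numbers, and compound 1 and compound 3 both lie lower by more than the scatter. Compound 4 `COc1ccc(C(C)(C)O)cc1-c1cn(C)c(=O)c2[nH]c(C(=O)NCc3ccc(C(=O)Nc4ccccc4N)cc3)cc12` keeps compound 2 except for one change (methoxy in place of hydrogen on an aromatic carbon), methoxy in place of hydrogen on an aromatic carbon, ortho to a large group and para to a 1-hydroxy-1-methylethyl group.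

Within the data shown here, no measured pair isolates this change. Compound 1 at 610 nM and compound 3 at 300 nM each carry an aromatic group joined through oxygen, but their chains also differ from that of compound 2, so they offer only a weak hint of direction. A small move toward stronger inhibition is expected, and the estimate is a 1.7-fold lower number from compound 2 to compound 4 (0.23 log units; within the scatter) in size, which would stay within the scatter. For compound 4 the expected value is 1300 nM (estimated range 450 nM to 3200 nM).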

Compound 4, half-maximal inhibitory concentration: 420 nM
The estimate for compound 4 lay 3.1-fold (0.49 log units) above the measured number, outside the stated range (below it).
By their numbers in this assay, from the lowest: compounds 3, 4 and 1 (each within the scatter of the next, the first and the last beyond it); then compound 2.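

In this assay, methoxy in place of hydrogen, on the aromatic carbon ortho to a large group and para to the 1-hydroxy-1-methylethyl group, gives a 5.2-fold lower number from compound 2 to compound 4 (0.72 log units; beyond the scatter). The earlier compounds shown here held no pair that isolated this position, so this is its first direct reading: with the rest of compound 2 unchanged, this one change moves the number toward stronger inhibition by more than the scatter. No evidence on the cause of this step is at hand.

The compounds shown leave open whether an ethoxy group, a fluorine atom or an amine at the same carbon would give a similar step. They also leave open whether methoxy would have the same effect on the chain of compound 1 or compound 3.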